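The source may report more compounds than this note shows. Statements on the series, on what has been measured and on what is new or still open speak of the compounds shown alone.

Compound 1 `COc1c(NS(=O)(=O)C2CC2)cc(-c2ccc3nc(NC(C)=O)nn3c2)cc1C(N)=O` was tested in a functional assay on HCT-116 cells (Homo sapiens) for antiproliferative activity, read by MTT assay, with a stated time of 72 h (a lower number here means a stronger inhibitor, a higher number a weaker inhibitor), where compound 1 gives 36300 nM. Among the two numbers obtained in this assay, this is the highest: compound 2 `COc1c(NS(=O)(=O)C2CC2)cc(-c2ccc3nc(NC(=O)C4CC4)sc3c2)cc1C(N)=O` gives 14500 nM, a gap that lies beyond the usual scatter. Compound 3 `COc1c(NS(=O)(=O)c2ccc(F)cc2)cc(-c2ccn3nc(N)nc3c2)cc1C(N)=O` reached only the limit of this assay, reported as > 50000 nM, so no number is known for it. Compound 4 `COc1c(NS(=O)(=O)c2ccc(F)cc2)cc(-c2ccc3nc(NC(C)=O)nn3c2)cc1C(N)=O` has not yet been measured; it differs from compound 1 in one place, with 4-fluorophenyl in place of cyclopropyl on a sulfonyl sulfur. Among the measured compounds shown here, no pair of measured compounds differs in exactly this way, so the size of the step cannot be read from a measured step. Compound 3, which carries the same (4-fluorophenyl)sulfonyl group on a different core, sits at the limit (the limit of > 50000 nM in this assay, at which 1 of the 3 values shown sits), which points toward a number no lower than that of compound 1. The estimate for compound 4 is 45000 nM, with a range from 15000 nM to 150000 nM. The expected step is a 1.2-fold higher number from compound 1 to compound 4 (0.09 log units; within the scatter), most likely none beyond the scatter and possibly a weakening, with a real chance that only a limit is reported.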

Compound 4, half-maximal inhibitory concentration: 25400 nM
The estimate for compound 4 lay 1.8-fold (0.25 log units) above the measured number, within the range that was stated.
By their numbers in this assay, from the lowest: compounds 2, 4 and 1 (each within the scatter of the next, the first and the last beyond it). At a limit, above all of these: compound 3.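

In this assay, putting 4-fluorophenyl in place of cyclopropyl on a sulfonyl sulfur gives a 1.4-fold lower number from compound 1 to compound 4 (0.16 log units; within the scatter), so on this core, an aromatic six-membered ring and a three-membered ring at this position cannot be told apart by this read-out. The (4-fluorophenyl)sulfonyl group therefore does not by itself carry a compound to the limit of the assay, as compound 4 holds this group and still gives a number. Compound 3, with the same group on a different core, stays at a limit: the limit of > 50000 nM in this assay, at which 1 of the 4 values shown sits.

The compounds shown compare the two groups on one core only, so whether the step stays this small on another core remains open. They also leave open how a methyl group, or a chain ending in an amine, would read on the same sulfonyl sulfur.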